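The compounds below may be only part of what the source reports. "The series", "measured", "known", "first", "only" and "open" are said of these compounds alone.

Working notes on the series.

The ring-fused compounds come first. Compound 1 `COc1ccc(C23CCC(=O)N2CCCO3)cc1` carries a methoxy group on the aromatic ring. In a functional assay on the whole organism (Central nervous system) with Mus musculus as the target (on this read-out lower numbers stand for an effect already at smaller amounts and higher numbers for an effect only at larger amounts of compound), compound 1 gives < 150 mg/kg, which is a limit of the assay and not a number. Compound 2 `Cc1ccc(C23CCC(=O)N2CCCO3)cc1` differs from compound 1 by methyl in place of methoxy on an aromatic carbon. In this assay compound 2 gives 160 mg/kg. The step between them, an at least 1.0-fold higher number from compound 1 to compound 2 (0.02 log units; that floor lies within the scatter), can only be stated as a floor because the limit of < 150 mg/kg in this assay, at which 1 of the 3 values shown sits, is all that compound 1 provides.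

Compound 3 `COc1ccc(C(=O)CCC(=O)NCCCO)cc1` has an open-chain core; how it differs from the core of compound 1 is not broken down here. In this assay compound 3 gives 800 mg/kg, the highest of the two numbers shown and well apart from compound 2, as the comparison given shows.

Compound 4 `Cc1ccc(C(=O)CCC(=O)NCCCO)cc1` is the open-chain counterpart of compound 2 and differs from compound 3 by methyl in place of methoxy on an aromatic carbon, the same change as made between compound 1 and compound 2, since the two place descriptions agree word for word. This change has been seen once so far, as an at least 1.0-fold higher number from compound 1 to compound 2 (0.02 log units; that floor lies within the scatter), a floor that lies within the scatter. On that basis, and on compound 3 at 800 mg/kg, the step from compound 3 to compound 4 is expected to be small, a 1.1-fold higher number from compound 3 to compound 4 (0.03 log units; within the scatter), with a slight lean toward the higher side. Compound 4 is accordingly estimated at 850 mg/kg in this assay, with a likely range from 450 mg/kg to 1600 mg/kg.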

Compound 4, dose for half-maximal effect: 700 mg/kg
The estimate for compound 4 lay 1.2-fold (0.08 log units) above the measured number; low and high end bracket the measured number.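

In this assay the change of methyl in place of methoxy on an aromatic carbon gives a 1.1-fold lower number from compound 3 to compound 4 (0.06 log units; within the scatter) on the open-chain core, so on this core the change leaves the number within the scatter. Beside this stands the ring-fused pair, where the step is known only as a floor, so the data neither show that the change carries over unaltered from one core to the other nor show that the two cores respond differently: the same change on two cores in this assay, an at least 1.0-fold higher number (0.02 log units; that floor lies within the scatter) from compound 1 to compound 2 and a 1.1-fold lower number (0.06 log units; within the scatter) from compound 3 to compound 4; the limit leaves it open whether they differ
The ring-fused side of this comparison stays unsettled, since compound 1 offers a limit of the assay and not a number: the limit of < 150 mg/kg in this assay, at which 1 of the 4 values shown sits.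

The compounds shown leave open how other groups at this place on the aromatic ring, such as a chlorine atom, a hydroxyl group or an amine, would behave on each of the two cores. Also open, on these data alone, is whether a carboxylic acid or a longer chain in the open-chain core would keep the numbers near those of compound 3 and compound 4, and whether any such result would carry over to the ring-fused core.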